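Isopropyl to cyclopentyl on an aromatic nitrogen

This account rests on a few compounds, and the source may have more. Where it says the series, first, only, none or still open, it means among the compounds named here.

In a functional assay on HeLa cells (Homo sapiens) for antiproliferative activity, read by CCK-8 assay, with a stated time of 72 h (on this read-out lower numbers stand for stronger inhibition and higher numbers for weaker inhibition), compound 1 `CCC(C)n1cnc2c(NCc3ccc(C(=O)Nc4ccccc4N)cc3)nc(Cl)nc21` gives 3030 nM, compound 2 `Nc1ccccc1NC(=O)c1ccc(Cn2cnc3c(Nc4ccccc4)nc(Cl)nc32)cc1` gives 2920 nM and compound 3 `CC(C)n1cnc2c(NCc3ccc(C(=O)Nc4ccccc4N)cc3)nc(Cl)nc21` gives 2130 nM. Compound 3 stands within the scatter of both other compounds, so no order can be read among the three numbers.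

The next compound is compound 4 `Nc1ccccc1NC(=O)c1ccc(CNc2nc(Cl)nc3c2ncn3C2CCCC2)cc1`, with cyclopentyl in place of isopropyl on an aromatic nitrogen.

Among the measured compounds shown here, one measured step bears on this change: a 1.4-fold lower number from compound 1 to compound 3 (0.15 log units; within the scatter), with hydrogen in place of methyl on a saturated chain carbon, two bonds along the chain from an aromatic nitrogen. That step is small and lies within the scatter. For the measured compounds named here, compound 2 differs from compound 3 in more than one place, so it gives no clean step. No shift beyond the scatter is therefore expected in this assay, and no direction is favoured. The estimated step is a 1.0-fold higher number from compound 3 to compound 4 (0.01 log units; within the scatter). For compound 4 the expected value is 2200 nM, with an estimated range from 1000 nM to 4500 nM.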

Compound 4, half-maximal inhibitory concentration: 3020 nM
For compound 4 the middle estimate is 1.4-fold (0.14 log units) below the measured one; low and high end bracket the measured number.
By their numbers in this assay, from the lowest: compounds 3, 2, 4 and 1 (each within the scatter of the next).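

Cyclopentyl in place of isopropyl on this aromatic nitrogen gives a 1.4-fold higher number from compound 3 to compound 4 (0.15 log units; within the scatter) in this assay, so a five-membered non-aromatic ring of carbon only, with 5 heavy atoms against 3, stays within the scatter of the open-chain group here. Cyclopentyl in place of sec-butyl gives a 1.0-fold lower number from compound 1 to compound 4 (0.00 log units; within the scatter) and likewise stays within the scatter, so the isopropyl, sec-butyl and cyclopentyl groups cannot be told apart at this position in this read-out. No available evidence explains this result.

Going by these compounds, whether an amine, a carboxylic acid or a longer chain on this nitrogen would shift the number beyond the scatter remains open. On these data alone, it is also open whether a ring larger than cyclopentyl, such as cyclohexyl, would stay within the scatter of compound 4.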